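The source may report more compounds than this note shows. Statements on the series, on what has been measured and on what is new or still open speak of the compounds shown alone.

Working notes on the series. Compound 1 `O=C(NC(=S)Nc1ccccc1)c1ccccc1F` shares its core with the rest of the set; in an assay on isolated protein for inhibition of polyamine deacetylase HDAC10 (Homo sapiens), read by fluorescence, tested at 100 uM (on this read-out higher numbers stand for more inhibition at the one concentration tested (going by the name of the read-out) and lower numbers for less inhibition), compound 1 gives "not active" (no number reported), reported without a number. Compound 2 `O=C(NC(=S)NCc1ccc(C(F)(F)F)cc1)c1ccccc1` in this assay also gives "not active" (no number reported), again with no number. Compound 3 `COc1cc(NC(=S)NC(=O)c2ccccc2)cc(OC)c1` in this assay gives 10%, a low read-out. Compound 4 `O=C(NC(=S)Nc1ccccc1)c1ccccc1` differs from compound 1 by hydrogen in place of fluoro on an aromatic carbon. Among the measured compounds shown here, no measured pair in the set differs in a single place, so no step size is known here. Given that compound 1 stands without a number and compound 3 gives 10%, the change from compound 1 to compound 4 is expected to stay within the scatter, in no clear direction. Compound 4 is estimated at 5%, within 0% to 15%, with a fair chance of a limit-only report.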

Compound 4, a percentage reported as inhibition, at one concentration (the size of the read-out at that concentration, not a potency): 15%
The estimate for compound 4 lay 10 percentage points below the measured number; the measured number falls inside the stated range.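

Among the compounds shown here, compound 1 has no number in this assay, so no step to compound 4 can be read. The compounds shown leave open what fluoro in place of hydrogen does to this read-out. No supporting evidence bears on this result.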